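Chain extension on the amide of a furan-bearing threonine derivative

A few compounds are considered here, and "the series" means these few. Any claim that something is new, unique, unknown or untested is made for them only; others in the source may bear on it.

Compound 1 `CCCCCCCCNC(=O)[C@@H](NC(=O)c1ccco1)[C@@H](C)O` was tested in a functional assay on SW-620 cells (Homo sapiens) for cytotoxicity, read by MTT assay, with a stated time of 48 h (a lower number here means a stronger inhibitor, a higher number a weaker inhibitor), and gave 200000 nM. Compound 2 `C/C=C/C=C/C(=O)N[C@H](C(=O)NCCCCCCCC)[C@@H](C)O` is its closest measured neighbour, and in this assay compound 2 gave 200000 nM. For the measured compounds named here, the only measured step, no change at the digits printed from compound 1 to compound 2 (within the scatter), shows the two compounds level with each other, so compound 1 stands at a weak position with no measured companion that improves on it.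

Compound 3 `CCCCCCCCCCCCNC(=O)[C@@H](NC(=O)c1ccco1)[C@@H](C)O` differs from compound 1 by butyl in place of hydrogen on a saturated chain carbon, eight bonds along the chain from an amide-type nitrogen. Going by the values given here, no measured step touches this part of the molecule; the one step in hand concerns the acyl group on the other amide and shows nothing beyond the scatter, so it offers no guidance in either direction for the longer chain. With both measured compounds weak and nothing to argue for a shift, compound 3 is expected to remain in the same weak region, with the expected step of a 1.3-fold lower number from compound 1 to compound 3 (0.12 log units; within the scatter) small and uncertain in direction. The estimate for compound 3 in this assay is 150000 nM, within a range from 30000 nM to 300000 nM.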

Compound 3, half-maximal inhibitory concentration: 87500 nM
Compound 3: the middle estimate sits 1.7-fold (0.23 log units) above what was measured; the measured number falls inside the stated range.
By their numbers in this assay, from the lowest: compound 3; then compounds 1 and 2 (each within the scatter of the next).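

In this assay, the saturated chain on the amide-type nitrogen proves to be a part of the molecule where the number can move (a 2.3-fold lower number from compound 1 to compound 3 (0.36 log units; beyond the scatter)). The only earlier step, on the acyl group, had shown nothing of the kind (no change at the digits printed from compound 1 to compound 2 (within the scatter)), so the butyl extension, eight bonds along the chain from that nitrogen, gives the first change in this set that lies beyond the scatter, though a modest one that still leaves compound 3 at a high number (87500 nM). Nothing measured here explains why the added butyl lowers the number, and no supporting evidence bears on the result.

With a single extension in hand, these compounds cannot show whether the trend continues with a still longer chain such as hexadecyl, or whether a chain of intermediate length would fall on the same line, and a chain ending in an amine or a carboxylic acid remains an open case. They also leave open whether the penta-1,3-dien-1-yl acyl group would behave as furan-2-yl does when paired with the longer chain of compound 3.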